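Chromatographic lipophilicity across an amide-linked quinoline series

A few compounds are considered here, and "the series" means these few. Any claim that something is new, unique, unknown or untested is made for them only; others in the source may bear on it.

Measured compounds:
Compound 1 `COc1ccc2nc(C)c(NC(=O)C(=O)Nc3cc(C)cc(C)c3)c(O)c2c1` — 3.76
Compound 2 `COc1cccc(NC(=O)COc2cc(C)nc3ccc(OC)cc23)c1` — 4.49

Of the compounds shown here, two have been measured in a physicochemical assay for lipophilicity, read by HPLC, in phosphate buffer, measured as chromatographic lipophilicity, at pH 7.4; on this read-out higher numbers stand for higher lipophilicity and lower numbers for lower lipophilicity. Compound 1 `COc1ccc2nc(C)c(NC(=O)C(=O)Nc3cc(C)cc(C)c3)c(O)c2c1` gives 3.76. Compound 2 `COc1cccc(NC(=O)COc2cc(C)nc3ccc(OC)cc23)c1` gives 4.49, the higher of the two numbers; the nearest number, that of compound 1, lies lower by a gap that is beyond the scatter. Among the measured compounds shown here, no two measured compounds differ in only one place, so no single step between them can be read.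

Compound 3 `COc1ccc2nc(C)cc(OCC(=O)Nc3noc(C)c3C)c2c1` has not yet been measured in this assay. Against compound 2 its difference is 4,5-dimethyl-1,2-oxazol-3-yl in place of 3-methoxyphenyl on an amide-type nitrogen. For the measured compounds named here, there is no measured pair that isolates this kind of exchange, so any expectation rests on the value of compound 2 alone and on the change itself. The step from compound 2 to compound 3 in this assay is expected to be downward and beyond the scatter, a number 0.89 log units lower from compound 2 to compound 3 (beyond the scatter). Compound 3 is therefore estimated at 3.6, with a range from 3 to 4.2.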

Compound 3, distribution coefficient: 3.3
Compound 3: middle estimate off by 0.30 log units, on the high side; the range from low to high includes it.
By their numbers in this assay, from the lowest: compound 3; then compound 1; then compound 2.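

In this assay, the exchange of 3-methoxyphenyl for 4,5-dimethyl-1,2-oxazol-3-yl on an amide-type nitrogen gives the only single step that can be read among these compounds: a number 1.19 log units lower from compound 2 to compound 3 (beyond the scatter). This shows that the read-out at this nitrogen depends strongly on the group it carries, even though the group that leaves, with 8 heavy atoms and 1 hydrogen-bond acceptor, and the group that enters, with 7 heavy atoms and 2 hydrogen-bond acceptors, differ only slightly in these counts. No measurement shown here gives a reason for this step.

Among the compounds shown here, the exchange alters the ring size, the hetero atoms and the substituents all at once, so their separate shares remain unknown, and no step to or from compound 1 can be read, as it differs from the others in more than one place. As far as these compounds go, how a plain phenyl group or an amine at the same nitrogen would compare with 3-methoxyphenyl and 4,5-dimethyl-1,2-oxazol-3-yl also stays open.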